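A Primary Benzylic Amine Replaces the Thiane in Compound 4

This account rests on a few compounds, and the source may have more. Where it says the series, first, only, none or still open, it means among the compounds named here.

Compound 3 `c1ccc2c(c1)CN[C@@H](CN(CCCCNC1CCSCC1)[C@H]1CCCc3cccnc31)C2` was tested in a functional assay on cells for agonist activity at C-X-C chemokine receptor type 4 (Homo sapiens), read by fluorescence and calcium flux, with a stated time of 90 s (a lower number here means that less compound is needed, a higher number that more compound is needed for the effect), and returns only a limit, > 30000 nM. Compound 1 `c1cncc(CNCCCCN(C[C@H]2Cc3ccccc3CN2)[C@H]2CCCc3cccnc32)c1` also gives only a limit, > 30000 nM. Compound 2 `c1ccc2c(c1)CN[C@@H](CN(CCCCNC1CCCCC1)[C@H]1CCCc3cccnc31)C2` likewise gives only a limit, > 30000 nM. All three values thus sit at the limit of > 30000 nM in this assay, at which 3 of the 3 values shown sit. The steps a step that the two limits leave unreadable from compound 1 to compound 2, a step that the two limits leave unreadable from compound 1 to compound 3 and a step that the two limits leave unreadable from compound 2 to compound 3 cannot be sized, so no exchange on that amine nitrogen has yet shown a readable effect. Compound 4 `NCc1ccccc1CN(C[C@H]1Cc2ccccc2CN1)[C@H]1CCCc2cccnc21` differs from compound 3 by a group of 8 heavy atoms (7 carbon, 1 nitrogen; one six-membered aromatic ring of carbon only) in place of a group of 10 heavy atoms (8 carbon, 1 nitrogen, 1 sulfur; one six-membered non-aromatic ring with 1 hetero atom), on a saturated chain carbon bound to an amine nitrogen. Because compounds 1, 2 and 3 all rest at the limit of > 30000 nM in this assay, at which 3 of the 3 values shown sit, compound 4 is expected to remain at the limit as well, with an estimated value of 30000 nM. The step of a number no higher from compound 3 to compound 4 (the limit leaves the size open) is accordingly expected to lie within the scatter.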

Compound 4, half-maximal effective concentration: > 30000 nM
Compound 4 was reported as a limit; the forecaster's own chance of this, stated with the estimate: 85%; the middle value lies on the limit itself.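

In this assay compound 4 gives only a limit, > 30000 nM, so its steps from compound 1, compound 2 and compound 3 cannot be read. The compounds shown leave open what concentration any of them would need for the effect, with every value resting on a single limit: the limit of > 30000 nM in this assay, at which 4 of the 4 values shown sit.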